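This account rests on a few compounds, and the source may have more. Where it says the series, first, only, none or still open, it means among the compounds named here.

Measured in an ADME assay on Vero cells (Chlorocebus sabaeus) for cytotoxicity, with a stated time of 5 days; a lower number here means a stronger inhibitor, a higher number a weaker inhibitor:
- compound 1 `C=CCNc1nc(N)nc2c1ncn2[C@H]1C[C@H](N=[N+]=[N-])[C@@H](CO)O1`: > 100000 nM
- compound 2 `[N-]=[N+]=N[C@H]1C[C@H](n2cnc3c(NC4CC4)nc(Cl)nc32)O[C@@H]1CO`: > 100000 nM
- compound 3 `COc1nc(OC)c2ncn([C@H]3C[C@H](N=[N+]=[N-])[C@@H](CO)O3)c2n1`: > 100000 nM

Compound 1 stands at the edge of what this assay reports. Compound 1 gives > 100000 nM, and that is a limit of the assay and not a number. The other two compounds offer no contrast, and the whole set reads the same way: the limit of > 100000 nM in this assay, at which 3 of the 3 values shown sit. For the measured compounds named here, no measured compound gives a number to rank it against compound 1.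

The next compound, compound 4 `C#CCNc1nc(N)nc2c1ncn2[C@H]1C[C@H](N=[N+]=[N-])[C@@H](CO)O1`, differs from compound 1 in one place: ethynyl in place of vinyl on a saturated chain carbon bound to a nitrogen on an aromatic ring. In words, ethynyl stands in place of vinyl on a saturated chain carbon bound to a nitrogen on an aromatic ring, so that allylamino becomes propargylamino.

Going by the values given here, no pair of measured compounds shows what a change of this kind does in this assay. The expectation is therefore for no step beyond the scatter, and compound 4 is expected to be reported as a limit too. That expectation rests on compound 1, with its limit of > 100000 nM. The expected step of a number no higher from compound 1 to compound 4 (the limit leaves the size open) is an estimate only. For compound 4 the estimated value is 100000 nM, with an expected range of 40000 nM to 200000 nM.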

Compound 4, half-maximal inhibitory concentration: > 100000 nM
Compound 4: no number, only a limit; the forecaster's own chance of this, stated with the estimate: 80%; the middle value lies on the limit itself.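

In this assay compound 4 gives > 100000 nM, which is a limit of the assay and not a number. For the compounds shown here, compound 1 also stands at a limit, and no step between compound 1 and compound 4 can be read. The compounds shown leave open what ethynyl in place of vinyl does here, because the whole set sits at one value: the limit of > 100000 nM in this assay, at which 4 of the 4 values shown sit.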